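Aryl variation on the shared core, toward compound 4

The source may report more compounds than this note shows. Statements on the series, on what has been measured and on what is new or still open speak of the compounds shown alone.

Compound 3 `CCC1=C(O)c2c(oc(-c3ccc(C)c(Cl)c3)cc2=O)C(CC)(CC)C1=O` gives 39 uM in a functional assay on KB cells (Homo sapiens) for antiproliferative activity, read by sulforhodamine B assay, with a stated time of 3 days (on this read-out lower numbers stand for an effect already at smaller amounts and higher numbers for an effect only at larger amounts of compound), and stands lowest of the two numbers seen so far. Compound 2 `CCC1=C(O)c2c(oc(-c3cccc(C)c3)cc2=O)C(CC)(CC)C1=O` gives 49.7 uM in this assay, a value within the scatter of compound 3. Compound 1 `CCC1=C(O)c2c(oc(-c3ccc(Br)cc3)cc2=O)C(CC)(CC)C1=O` gives > 48.1 uM in this assay, which is a limit and not a number (the limit of > 48.1 uM in this assay, at which 1 of the 3 values shown sits). Compound 4 `CCC1=C(O)c2c(oc(-c3ccc(O)c(C)c3C)cc2=O)C(CC)(CC)C1=O` is not yet measured; it differs from compound 3 by 4-hydroxy-2,3-dimethylphenyl in place of 3-chloro-4-methylphenyl on an aromatic carbon. Among the compounds with values here, the steps that bear on this change are the earlier aryl replacements: a 1.3-fold lower number from compound 2 to compound 3 (0.11 log units; within the scatter) and an at least 1.2-fold lower number from compound 1 to compound 3 (0.09 log units; that floor lies within the scatter), while a step that the limit leaves unreadable from compound 1 to compound 2. Neither readable step leaves the scatter, so no step beyond the scatter is expected in this assay, in either direction. Compound 4 is therefore expected to give about 40 uM in this assay, between 15 uM and 110 uM. The expected step is a 1.0-fold higher number from compound 3 to compound 4 (0.01 log units; within the scatter).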

Compound 4, concentration for half-maximal effect: 6.5 uM
Beside the measured number, compound 4's estimate is 6.2-fold (0.79 log units) above it; the whole stated range lies above it.
By their numbers in this assay, from the lowest: compound 4; then compounds 3 and 2 (each within the scatter of the next).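

At this place on the shared core, the aryl group can move the number beyond the scatter in this assay: 4-hydroxy-2,3-dimethylphenyl gives a 6.0-fold lower number from compound 3 to compound 4 (0.78 log units; beyond the scatter) and a 7.6-fold lower number from compound 2 to compound 4 (0.88 log units; beyond the scatter), whereas the earlier readable aryl steps stayed within it. Of the compounds with a number or limit here, only compound 4 has a hydrogen-bond donor on this aryl group. Compound 1 stands at a limit and not a number, and its step reads an at least 7.4-fold lower number from compound 1 to compound 4 (0.86 log units; beyond the scatter): the limit of > 48.1 uM in this assay, at which 1 of the 4 values shown sits.

As far as these compounds go, the hydroxy and the two methyl groups enter together, so their separate shares in the step remain open. From the compounds shown here alone, how an amine or a carboxylic acid in place of the hydroxy group would read also remains open.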